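Bromo for Cyclopentyl: Expected Cytotoxicity of Compound 4

A few compounds are considered here, and "the series" means these few. Any claim that something is new, unique, unknown or untested is made for them only; others in the source may bear on it.

Of the compounds shown here, three sharing one core have been tested in an ADME assay on MDCK cells (Canis lupus familiaris) for cytotoxicity, read by microscopy, with a stated time of 48 h; on this read-out lower numbers stand for higher toxicity in this test and higher numbers for lower toxicity in this test. Compound 1 `C[C@H]1[C@H](NCc2cc(C3CC3)cs2)C[C@H]2C[C@@H]1C2(C)C` gives 25000 nM in this assay. Within the data shown here, compound 2 `CCCc1csc(CN[C@@H]2C[C@H]3C[C@@H]([C@H]2C)C3(C)C)c1` gives 12500 nM, and the single step between them, a 2.0-fold lower number from compound 1 to compound 2 (0.30 log units; within the scatter), does not rise above the scatter of the measurement. Compound 3 `C[C@H]1[C@H](NCc2sccc2C2CCCC2)C[C@H]2C[C@@H]1C2(C)C` gives 12500 nM, the same number as compound 2 at the digits shown, while compound 1 stands within the scatter of both; on the numbers so far, the three compounds cannot be told apart with confidence.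

Compound 4 `C[C@H]1[C@H](NCc2sccc2Br)C[C@H]2C[C@@H]1C2(C)C` has not yet been measured. It differs from compound 3 in one place: bromo in place of cyclopentyl on an aromatic carbon. Among the measured compounds shown here, no measured step involves a bromo group, so the only guidance is the step from compound 1 to compound 2, which exchanged one carbon group for another on the same aromatic carbon and stayed within the scatter. On that basis the expected step of a 2.0-fold higher number from compound 3 to compound 4 (0.30 log units; within the scatter) is small, with no firm direction. Compound 4 is therefore estimated to give 25000 nM in this assay, with a plausible range from 6250 nM to 100000 nM.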

Compound 4, minimum cytotoxic concentration: 50000 nM
Compound 4: the middle estimate sits 2.0-fold (0.30 log units) below what was measured; the range from low to high includes it.
By their numbers in this assay, from the lowest: compounds 2, 3, 1 and 4 (each within the scatter of the next, the first and the last beyond it).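

At this position, on an aromatic carbon next to the ring atom that bears a large group, putting bromo in place of cyclopentyl gives a 4.0-fold higher number from compound 3 to compound 4 (0.60 log units; beyond the scatter) in this assay, and this is the only single change shown so far that rises above the scatter. Since a higher number here stands for lower toxicity in this test, compound 4 is less toxic in this test than compound 3, and the change swaps a ring of 5 heavy atoms for 1 heavy atom, with no hydrogen-bond donor, hydrogen-bond acceptor or net charge on either side. No measurement at hand explains the size or direction of this step.

From the compounds shown here alone, a single pair cannot separate the loss of cyclopentyl from the arrival of bromo, so it stays open whether the higher number follows from removing the ring or from the bromine itself. Methyl or chloro at this position could help to separate the two, while an amine or a carboxylic acid there would show how this read-out responds to a very different kind of group.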